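The source may hold more compounds than are shown below. What is called first, only, known or untested is meant among the compounds shown, and "the series" means these compounds.

Measured compounds:
compound 1 `COc1cc2c(Oc3ccc(NC(=O)c4cc(-c5cccc(Cl)c5)nc5ccccc45)cc3F)ccnc2cc1OCCCN1CCCCC1` — 11 nM
compound 2 `COc1cc2c(Oc3ccc(NC(=O)c4cc(-c5ccc(C)cc5)nc5ccc(F)cc45)cc3F)ccnc2cc1OCCCN1CCCCC1` — 260 nM

In a functional assay on NCI-H460 cells (Homo sapiens) for cytotoxicity, read by MTT assay, with a stated time of 72 h (on this read-out higher numbers stand for weaker inhibition and lower numbers for stronger inhibition), compound 2 gives the highest of the two numbers; compound 1 gives a lower one, and the gap between them lies beyond the scatter. For the measured compounds named here, compound 1 and compound 2 differ in more than one place, so no single step is defined between them.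

Compound 3 `COc1cc2c(Oc3ccc(NC(=O)c4cc(-c5ccc(Cl)cc5Cl)nc5ccc(F)cc45)cc3F)ccnc2cc1OCCCN1CCCCC1` follows from compound 2 by 2,4-dichlorophenyl in place of 4-methylphenyl on an aromatic carbon. Going by the values given here, the data hold no step isolating this change. Compound 3 is expected to give 60 nM (range 15 nM to 250 nM), a step of a 4.3-fold lower number from compound 2 to compound 3 (0.64 log units; beyond the scatter) toward stronger inhibition, leaning on the lower number of compound 1 11 nM, which also carries a chlorine-bearing ring.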

Compound 3, half-maximal inhibitory concentration: 310 nM
Compound 3: middle estimate off by 5.2-fold (0.71 log units), on the low side; the whole stated range lies below it.
By their numbers in this assay, from the lowest: compound 1; then compounds 2 and 3 (each within the scatter of the next).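

In this assay, 2,4-dichlorophenyl in place of 4-methylphenyl on this aromatic carbon next to the ring nitrogen gives a 1.2-fold higher number from compound 2 to compound 3 (0.08 log units; within the scatter) and so does not separate the two groups. At this position on the core shared by compound 2 and compound 3, two chlorine atoms on the phenyl ring thus leave the read-out where the methyl-bearing ring puts it. Nothing at hand accounts for this flat step.

Open, as far as these compounds go, is whether a group of another kind on this carbon, such as an amine or a carboxylic acid, would shift the number beyond the scatter. Also open, from the compounds shown here alone, is whether a phenyl ring carrying a single chlorine would behave as these two groups do on this core.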